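One Number, One Swap: From Compound 2 to Compound 3

The compounds below may be only part of what the source reports. "The series", "measured", "known", "first", "only" and "open" are said of these compounds alone.

Compound 1 `Cc1ccc(NC(=O)C(Cl)Cl)cc1` has the entry "not determined" (no result reported) in a functional assay on BGC-823 cells (Homo sapiens) for antiproliferative activity, read by MTT assay, with a stated time of 72 h (a lower number here means a stronger inhibitor, a higher number a weaker inhibitor), and so offers no comparison. For the measured compounds named here, compound 2 `O=C(Nc1ccc(I)cc1)C(Cl)Cl` gives 222000 nM in this assay and this is the only number available, so it cannot yet be ranked against anything. Compound 3 `O=C(Nc1ccc(SC(F)(F)F)cc1)C(Cl)Cl` has not been measured. It carries (trifluoromethyl)sulfanyl in place of iodo on an aromatic carbon and the rest of the structure stays the same. Going by the values given here, compound 2 is a weak inhibitor at 222000 nM and no measured step exists to guide a forecast. A modest change is therefore expected, an estimated move toward stronger inhibition a 2.2-fold lower number from compound 2 to compound 3 (0.35 log units; beyond the scatter) rather than a large jump. For compound 3 the estimated value in this assay is 100000 nM with an expected range from 25000 nM to 300000 nM as the measurement is awaited.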

Compound 3, half-maximal inhibitory concentration: 203000 nM
Compound 3: the middle estimate sits 2.0-fold (0.31 log units) below what was measured; the measured number falls inside the stated range.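

In this assay, replacing iodo with (trifluoromethyl)sulfanyl on this aromatic carbon gives a 1.1-fold lower number from compound 2 to compound 3 (0.04 log units; within the scatter). The entering group has 5 heavy atoms and 1 hydrogen-bond acceptor, whereas the iodo group has 1 heavy atom and no hydrogen-bond acceptor, yet compound 2 and compound 3 read as equal and both remain weak inhibitors, so this one swap shows that these two quite different groups cannot be told apart here. The data available offer nothing that explains why the two groups read alike.

Going by these compounds, two groups are a narrow sample of this position, so it remains open whether an amine or a carboxylic acid there would move the number beyond the scatter. On these data alone, it is equally open whether a change elsewhere in the shared core would matter more than any change at this position.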